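Moving the Chlorine Around the Phenyl Ring

The source may report more compounds than this note shows. Statements on the series, on what has been measured and on what is new or still open speak of the compounds shown alone.

For the measured compounds named here, compound 2 `NS(=O)(=O)NCCC1CCN(c2cc(-c3ccc(Cl)cc3)ncn2)CC1` gives 19700 nM in a functional assay on MCF7 cells (Homo sapiens) for antiproliferative activity, read by sulforhodamine B assay, with a stated time of 48 h (a higher number here means a weaker inhibitor of growth, a lower number a stronger inhibitor of growth), the lowest of the two numbers measured so far, while compound 1 `COc1ccc(-c2cc(N3CCC(CCNS(N)(=O)=O)CC3)ncn2)cc1` gives 56600 nM in this assay. Going by the values given here, the only measured step, a 2.9-fold lower number from compound 1 to compound 2 (0.46 log units; beyond the scatter), replaced one group by another on the same carbon and says nothing about moving the chlorine. Compound 3 `NS(=O)(=O)NCCC1CCN(c2cc(-c3cccc(Cl)c3)ncn2)CC1` differs from compound 2 only in that (3-chlorophenyl in place of 4-chlorophenyl on an aromatic carbon). Among the compounds with values here, with no measured step bearing on such a change, no step beyond the scatter is expected: a 1.0-fold higher number from compound 2 to compound 3 (0.01 log units; within the scatter). Compound 3 is therefore estimated at 20000 nM, within 7000 nM to 60000 nM.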

Compound 3, concentration for 50% growth inhibition: 31200 nM
Compound 3: middle estimate off by 1.6-fold (0.19 log units), on the low side; low and high end bracket the measured number.
By their numbers in this assay, from the lowest: compounds 2, 3 and 1 (each within the scatter of the next, the first and the last beyond it).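

Moving the chlorine from 4-chlorophenyl to 3-chlorophenyl gives a 1.6-fold higher number from compound 2 to compound 3 (0.20 log units; within the scatter) in this assay so these two placements cannot be told apart here. Replacing 4-methoxyphenyl with 3-chlorophenyl gives a 1.8-fold lower number from compound 1 to compound 3 (0.26 log units; within the scatter) so of the two chlorine compounds, only compound 2 has a step from compound 1 beyond the scatter. No measurement available here explains these numbers.

On these data alone, whether an amine or a carboxylic acid in place of the chlorine would give a step beyond the scatter remains open.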